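From tert-butoxy to ethoxy at a measuring limit

The source may hold more compounds than are shown below. What is called first, only, known or untested is meant among the compounds shown, and "the series" means these compounds.

In a physicochemical assay for lipophilicity, at pH 7.4 (on this read-out lower numbers stand for lower lipophilicity and higher numbers for higher lipophilicity), compound 1 `Cc1cc(NC(=O)c2c(F)cccc2F)nn1Cc1cc(Cl)ccc1OCc1ccccc1` gives > 3.7, which is a limit of the assay and not a number. Compound 2 `Cc1cc(NC(=O)OC(C)(C)C)nn1Cc1cc(Cl)ccc1OCc1ccccc1` gives > 3.7, again a limit and not a number. The evidence so far is the limit of > 3.7 in this assay, at which 2 of the 2 values shown sit.

Compound 3 `CCOC(=O)Nc1cc(C)n(Cc2cc(Cl)ccc2OCc2ccccc2)n1` has not yet been measured. It differs from compound 2 in one place: ethyl in place of tert-butyl on an oxygen next to a carbonyl group. Among the measured compounds shown here, the one measured step, a step that the two limits leave unreadable from compound 1 to compound 2, also changes a group on a carbonyl carbon, but it gives no size to carry over.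

Starting from compound 2, whose > 3.7 is a limit, the smaller chain leads to the expectation of a modest fall in this assay. The expected size is a step that the limit leaves unreadable from compound 2 to compound 3, and that estimate is uncertain with no readable step behind it. this assay may well return only a limit again. For compound 3 the estimated value is 4.2, with an expected range from 3.6 to 4.8.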

Compound 3, distribution coefficient: > 3.7
Compound 3: only a limit was reported; the forecaster's own chance of this, stated with the estimate: 70%; the middle value is on the limit's open side.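

In this assay, among the compounds shown here, compound 3 gives > 3.7, which is a limit of the assay and not a number, so no step among compound 1, compound 2 and compound 3 can be read. The compounds shown leave open how far apart these three really lie, and whether tert-butoxy to ethoxy changes the read-out at all.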